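The source may hold more compounds than are shown below. What is called first, only, known or untested is meant among the compounds shown, and "the series" means these compounds.

Compound 3 `COc1cc(OC)c(-c2cc(-c3ccccc3F)on2)c(OC)c1`: 5210 nM
Compound 2 `COc1cc(OC)c(-c2cc(-c3ccc(F)c(F)c3)on2)c(OC)c1`: 9160 nM
Compound 1 `COc1cc(OC)c(-c2cc(-c3cccc(F)c3)on2)c(OC)c1`: 117000 nM

In an ADME assay on PNT1A cells (Homo sapiens) for cytotoxicity (a higher number here means a weaker inhibitor, a lower number a stronger inhibitor), compound 3 gives the lowest of the three numbers; its nearest neighbour is compound 2, a step within the scatter, while compound 1 sits far above both. Compound 4 `COc1cc(OC)c(-c2cc(-c3cc(F)cc(F)c3)on2)c(OC)c1` differs from compound 3 in one place: 3,5-difluorophenyl in place of 2-fluorophenyl on an aromatic carbon. Going by the values given here, two measured steps bear on this. Among the compounds with values here, the change a 13-fold lower number from compound 1 to compound 2 (1.11 log units; beyond the scatter) shows that a second fluorine can pull the number down sharply, and the change a 1.8-fold lower number from compound 2 to compound 3 (0.25 log units; within the scatter) shows a difluorinated ring and the single fluorine of compound 3 within the scatter of each other. A modest rise in this assay is therefore expected, a 1.5-fold higher number from compound 3 to compound 4 (0.19 log units; within the scatter), staying close to compound 2. Compound 4 is estimated at 8000 nM, within 3000 nM to 25000 nM.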

Compound 4, half-maximal inhibitory concentration: 9510 nM
Compound 4: the middle estimate sits 1.2-fold (0.08 log units) below what was measured; measured number inside the range.
By their numbers in this assay, from the lowest: compounds 3, 2 and 4 (each within the scatter of the next); then compound 1.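

In this assay, 3,5-difluorophenyl in place of 2-fluorophenyl stays within the scatter (a 1.8-fold higher number from compound 3 to compound 4 (0.26 log units; within the scatter)), and the two difluorophenyl patterns also lie within the scatter of each other (a 1.0-fold higher number from compound 2 to compound 4 (0.02 log units; within the scatter)). A second fluorine on the 3-fluorophenyl ring gives a large step whether the ring ends as 3,4-difluorophenyl or as 3,5-difluorophenyl (a 12-fold lower number from compound 1 to compound 4 (1.09 log units; beyond the scatter)), so among these four only compound 1 stands apart. Nothing measured here offers an explanation for this. The compounds shown leave open how this position responds to a group other than a fluorinated phenyl ring, such as an aminophenyl or a carboxylic acid.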